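The source may hold more compounds than are shown below. What is called first, only, known or untested is meant among the compounds shown, and "the series" means these compounds.

In a functional assay on HepG2 cells (Homo sapiens) for antiproliferative activity, read by MTT assay, with a stated time of 48 h (a higher number here means a weaker inhibitor, a lower number a stronger inhibitor), compound 1 `Clc1cccc(Nc2ncnc3ccc(NCc4cccnc4)cc23)c1` gives 4140 nM, the lowest of the two numbers measured. Compound 2 `O=C(/C=C/c1cccnc1)Nc1ccc2ncnc(Nc3cccc(Cl)c3)c2c1`, which carries an amide-linked pyridinyl ethenyl group on the shared core, gives 9120 nM in this assay, a higher number than compound 1 and beyond the scatter. Compound 3 `O=C(/C=C/c1cccs1)Nc1ccc2ncnc(Nc3cccc(Cl)c3)c2c1` has not yet been measured; it differs from compound 1 by (2-(thiophen-2-yl)ethenyl)carbonyl in place of (pyridin-3-yl)methyl on a nitrogen on an aromatic ring. Given that compound 2 gives 9120 nM, the step of a 1.9-fold higher number from compound 1 to compound 3 (0.29 log units; within the scatter) is expected to be a modest weakening beyond the scatter. Compound 3 is therefore estimated at 8000 nM, with a range from 3500 nM to 18000 nM.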

Compound 3, half-maximal inhibitory concentration: 10400 nM
Compound 3: the middle estimate sits 1.3-fold (0.11 log units) below what was measured; measured number inside the range.
By their numbers in this assay, from the lowest: compound 1; then compounds 2 and 3 (each within the scatter of the next).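

In this assay, (2-(thiophen-2-yl)ethenyl)carbonyl in place of (pyridin-3-yl)methyl on the nitrogen gives a 2.5-fold higher number from compound 1 to compound 3 (0.40 log units; beyond the scatter), a modest weakening beyond the scatter. Thiophen-2-yl in place of pyridin-3-yl on the double-bonded chain carbon gives a 1.1-fold higher number from compound 2 to compound 3 (0.06 log units; within the scatter), so these two rings cannot be told apart on this chain. Nothing measured here accounts for either step. Going by these compounds, it remains open whether a phenyl ring in place of thiophen-2-yl would read the same, and whether a saturated chain in place of the ethenyl group would change the number.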